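Thiophen-3-yl in place of bromo on the shared core

The source may report more compounds than this note shows. Statements on the series, on what has been measured and on what is new or still open speak of the compounds shown alone.

Compound 2 `CC(C)(C)Cc1c(Br)sc(N)c1C(=O)c1ccc(Cl)cc1` gives 1% in an assay on CHO cells for displacement of a labelled ligand from adenosine receptor A1 (Homo sapiens), read by scintillation counting, tested at 10 uM (on this read-out higher numbers stand for more inhibition at the one concentration tested (going by the name of the read-out) and lower numbers for less inhibition), and stands level with compound 1 `CC(C)(C)Cc1c(-c2ccccn2)sc(N)c1C(=O)c1ccc(Cl)cc1`, which gives 1% in this assay. Among the measured compounds shown here, the one step measured, no change at the digits printed from compound 1 to compound 2 (within the scatter), came from bromo in place of pyridin-2-yl on an aromatic carbon and was flat within the scatter. Compound 3 `CC(C)(C)Cc1c(-c2ccsc2)sc(N)c1C(=O)c1ccc(Cl)cc1` carries thiophen-3-yl in place of bromo on an aromatic carbon. For the measured compounds named here, only that flat step bears on this change, pyridin-2-yl and bromo at the same aromatic carbon having given the same read-out, so the expected step is a number 2 percentage points higher from compound 2 to compound 3 (within the scatter), none beyond the scatter. Compound 3 is estimated at 3%, range -8% to 16%.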

Compound 3, a percentage reported as inhibition, at one concentration (the size of the read-out at that concentration, not a potency): 2%
The estimate for compound 3 lay 1 percentage points above the measured number, within the range that was stated.
By their numbers in this assay, from the lowest: compounds 1, 2 and 3 (each within the scatter of the next).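

In this assay, thiophen-3-yl at this aromatic carbon, next to the ring sulfur, gives a number 1 percentage points higher from compound 2 to compound 3 (within the scatter) and a number 1 percentage points higher from compound 1 to compound 3 (within the scatter). Bromo, pyridin-2-yl and thiophen-3-yl therefore all lie within the scatter of one another at this position, so neither swapping one aromatic ring for the other nor replacing bromo with a ring separates these compounds here. Nothing available accounts for this flat read-out.

As far as these compounds go, whether an amine or a carboxylic acid at this carbon would move the read-out remains open, as does the effect of replacing the neopentyl group elsewhere on the shared core.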